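A quinoline urea series and its cytotoxicity on fibroblasts

This account rests on a few compounds, and the source may have more. Where it says the series, first, only, none or still open, it means among the compounds named here.

Compound 1 `Cc1cc(NC(=O)Nc2ccc(C)c(Cl)c2)c2ccccc2n1`: > 25000 nM, a limit of the assay.
Compound 2 `Cc1cc(NC(=O)Nc2ccc(C(=O)O)cc2)c2ccccc2n1`: > 25000 nM, a limit of the assay.
Compound 3 `Cc1cc(NC(=O)Nc2ncccc2C)c2ccccc2n1`: > 25000 nM, a limit of the assay.

In an ADME assay on BJ cells (Homo sapiens) for cytotoxicity, with a stated time of 72 h (on this read-out lower numbers stand for an effect already at smaller amounts and higher numbers for an effect only at larger amounts of compound), compound 3 reaches only a limit, and the same holds for the other two: the limit of > 25000 nM in this assay, at which 3 of the 3 values shown sit. Compound 3 therefore stands at the same limit as every value shown, with no number to set it apart. Compound 4 `Cc1cc(NC(=O)Nc2ccc(N)cc2)c2ccccc2n1` differs from compound 3 in one place: 4-aminophenyl in place of 3-methylpyridin-2-yl on an amide-type nitrogen. For the measured compounds named here, no step between measured compounds is available to gauge this change. The expectation is that the step that the limit leaves unreadable from compound 3 to compound 4 stays within the scatter, as all three shown compounds sit at the limit. For compound 4 the estimate in this assay is 30000 nM, between 12000 nM and 100000 nM, most likely reported again as a limit.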

Compound 4, half-maximal effective concentration: > 25000 nM
Compound 4: no number, only a limit (the forecaster's own chance of this, stated with the estimate: 80%); the middle value is on the limit's open side.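

No step from compound 2 or compound 3 to compound 4 can be read, since each of these compounds gives only a limit: the limit of > 25000 nM in this assay, at which 4 of the 4 values shown sit. The compounds shown leave open what change in this series, if any, would bring a value off that limit.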